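Quinazoline ethers: swapping the aryloxy group and cell tolerance

The source may report more compounds than this note shows. Statements on the series, on what has been measured and on what is new or still open speak of the compounds shown alone.

Measured compounds:
compound 1, `COc1ccccc1Oc1nc(Nc2ccc(C#N)cc2)nc2ccccc12`, 150000 nM
compound 2, `N#Cc1ccc(Nc2nc(Oc3ccc(Cl)cc3Cl)c3ccccc3n2)cc1`, 32000 nM

Among the measured compounds shown here, in an ADME assay on MT4 cells (Homo sapiens) for cytotoxicity, read by MTT assay, with a stated time of 4 days (a lower number here means that less compound is tolerated, a higher number that more compound is tolerated), compound 2 gives the lowest of the two numbers; its nearest neighbour is compound 1 at 150000 nM, and the only measured step, a 4.7-fold lower number from compound 1 to compound 2 (0.67 log units; beyond the scatter), is beyond the scatter. The next compound, compound 3, `N#Cc1ccc(Nc2nc(Oc3ccc(F)cc3)c3ccccc3n2)cc1`, is not yet measured. It differs from compound 2 as follows: 4-fluorophenyl in place of 2,4-dichlorophenyl on an oxygen on an aromatic ring. For the measured compounds named here, only the step from compound 1 to compound 2 bears on this change, and it concerns the same oxygen-linked ring. Since both chlorines leave and a single fluorine enters, compound 3 is expected to move part of the way back toward compound 1, so a modest rise in this assay is expected, a 2.5-fold higher number from compound 2 to compound 3 (0.40 log units; beyond the scatter). Compound 3 is therefore estimated at 80000 nM, with a likely range from 30000 nM to 200000 nM.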

Compound 3, half-maximal cytotoxic concentration: > 351000 nM
Compound 3 ended at the assay's limit; the forecaster's own chance of this, stated with the estimate: 20%; middle value at least 4.3-fold (0.64 log units) from the limit.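

In this assay, compound 3 reads as a limit and not as a number: the limit of > 351000 nM in this assay, at which 1 of the 3 values shown sits. Putting 4-fluorophenyl in place of 2,4-dichlorophenyl gives an at least 10-fold higher number from compound 2 to compound 3 (1.04 log units; beyond the scatter), and putting it in place of 2-methoxyphenyl gives an at least 2.3-fold higher number from compound 1 to compound 3 (0.36 log units; beyond the scatter). The earlier pair showed only a fall from compound 1, whereas these steps show that the group on this oxygen can move the number in either direction from compound 1, with compound 2 on one side and compound 3 on the other.

Going by these compounds, whether the rise belongs to the loss of the chlorines or to the entry of the fluorine stays open, as the two change together, and a plain phenyl or a 4-chlorophenyl on the same oxygen would separate them. On these data alone, how an amine or a carboxylic acid on this ring would read also stays open.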